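From 1,2-dihydroxyethyl to dioxolanyl: compound 2 to compound 3

This account rests on a few compounds, and the source may have more. Where it says the series, first, only, none or still open, it means among the compounds named here.

- compound 1 `O=C1c2c[n+]([O-])c3ccccc3c2C(=O)c2c1c1ccccc1n2Cc1cn(C[C@H](O)CO)nn1`: 1030 nM
- compound 2 `O=C1c2c[n+]([O-])c3ccccc3c2C(=O)c2c1c1ccccc1n2Cc1cn(CC(O)CO)nn1`: 880 nM

In a functional assay on A549 cells (Homo sapiens) for cytotoxicity, read by MTT assay, with a stated time of 72 h (on this read-out lower numbers stand for stronger inhibition and higher numbers for weaker inhibition), compound 2 gives 880 nM, within the scatter of compound 1 at 1030 nM. The next structure, compound 3 `CC1(C)OC[C@H](Cn2cc(Cn3c4c(c5ccccc53)C(=O)c3c[n+]([O-])c5ccccc5c3C4=O)nn2)O1`, differs from compound 2 as follows: 2,2-dimethyl-1,3-dioxolan-4-yl in place of 1,2-dihydroxyethyl on a saturated chain carbon bound to an aromatic nitrogen. The 2,3-dihydroxypropyl group thus gives way to (2,2-dimethyl-1,3-dioxolan-4-yl)methyl, on a saturated chain carbon bound to an aromatic nitrogen. Within the data shown here, the only measured step, a 1.2-fold lower number from compound 1 to compound 2 (0.07 log units; within the scatter), lies within the scatter and touches only (the fact that one of compounds 1 and 2 is drawn with a defined configuration and the other without, at the place where they differ). Among the measured compounds shown here, no measurement yet tests the exchange itself, so the data indicate no direction. Taking compound 2 at 880 nM as the anchor, no shift beyond the scatter is expected in this assay, though the range is kept wide. The expected step is a 1.1-fold lower number from compound 2 to compound 3 (0.04 log units; within the scatter). For compound 3 the estimated value is 800 nM, with an expected range of 270 nM to 2400 nM.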

Compound 3, half-maximal inhibitory concentration: 340 nM
Beside the measured number, compound 3's estimate is 2.4-fold (0.37 log units) above it; measured number inside the range.
By their numbers in this assay, from the lowest: compound 3; then compounds 2 and 1 (each within the scatter of the next).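

In this assay, among these compounds, the exchange of 1,2-dihydroxyethyl for 2,2-dimethyl-1,3-dioxolan-4-yl on a saturated chain carbon bound to an aromatic nitrogen is the first change here to move the number beyond the scatter, with a 2.6-fold lower number from compound 2 to compound 3 (0.41 log units; beyond the scatter) and, against the defined diol, a 3.0-fold lower number from compound 1 to compound 3 (0.48 log units; beyond the scatter). The earlier pair differed only in drawn configuration and stayed within the scatter, so this position responds to a change of the group itself, not only to how its stereocentre is drawn. Nothing on hand bears on why the dioxolanyl group gives the lower number.

As far as these compounds go, whether the ring, the methyl groups or the loss of both hydrogen-bond donors carries the step remains open. An unsubstituted 1,3-dioxolan-4-yl group, a 2,3-dimethoxypropyl group or an amine at this place would begin to separate these.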